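Triazole exchange from compound 2 to compound 3

The compounds below may be only part of what the source reports. "The series", "measured", "known", "first", "only" and "open" are said of these compounds alone.

Measured so far in an ADME assay on NIH3T3 cells (Mus musculus) for cytotoxicity (a higher number here means that more compound is needed for the effect, a lower number that less compound is needed), with one compound still open

- compound 1 `Cc1cc(Oc2cccc(Cn3cncn3)c2)cc(C)c1Cl` gives 75900 nM
- compound 2 `Cc1cc(Oc2cccc(Cn3nccn3)c2)cc(C)c1Cl` gives > 100000 nM as a limit of the assay
- compound 3 `Cc1cc(Oc2cccc(Cn3cnnc3)c2)cc(C)c1Cl` has no value yet

Compound 2 sits at the limit of > 100000 nM in this assay, at which 1 of the 2 values shown sits, and so has a limit rather than a number. The next change is 4H-1,2,4-triazol-4-yl in place of 2H-1,2,3-triazol-2-yl on a saturated chain carbon bound to an aromatic carbon with 4H-1,2,4-triazol-4-yl in place of 2H-1,2,3-triazol-2-yl on a saturated chain carbon bound to an aromatic carbon. Among the measured compounds shown here, one measured step bears on it, also an exchange of one triazole for another: an at least 1.3-fold higher number from compound 1 to compound 2 (0.11 log units; that floor lies within the scatter). For the measured compounds named here, with that step as the only guide, no step beyond the scatter is expected in this assay and no direction can be given. The expected size is an at least 1.1-fold lower number from compound 2 to compound 3 (0.04 log units; that floor lies within the scatter) and this stays an estimate. For compound 3 the estimated value is 90000 nM with an expected range of 45000 nM to 180000 nM as the likely span.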

Compound 3, half-maximal effective concentration: > 100000 nM
Compound 3: a limit, no number; the forecaster's own chance of this, stated with the estimate: 45%; middle value at least 1.1-fold (0.04 log units) away from the limit.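

In this assay compound 3 gives a limit and not a number (> 100000 nM). Measured against the 1H-1,2,4-triazol-1-yl group, the 4H-1,2,4-triazol-4-yl group on the saturated chain carbon gives only a floor within the scatter (an at least 1.3-fold higher number from compound 1 to compound 3 (0.11 log units; that floor lies within the scatter)). The step between compound 2 and compound 3 cannot be read, so this position now shows a second triazole exchange that yields no readable difference, with most of the series at the ceiling: the limit of > 100000 nM in this assay, at which 2 of the 3 values shown sit.

Still open, from the compounds shown here alone, is where compound 2 and compound 3 truly lie, and whether either differs from compound 1 by more than the scatter. Also open, going by these compounds, is whether an amine or a carboxylic acid in place of the triazole on this chain carbon would give a value inside the range of the assay.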